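Cell toxicity notes on compounds 1 to 3

The compounds below may be only part of what the source reports. "The series", "measured", "known", "first", "only" and "open" are said of these compounds alone.

Measured so far:
compound 1 `O=C(Nc1cccc(-n2cc(-c3ccncc3)c(-c3ccc(Cl)c(O)c3)n2)c1)Nc1ccc(Cl)c(Cl)c1` gives > 32500 nM
compound 2 `COc1cc(-c2nn(-c3cccc(NC(=O)c4ccc(Cl)c(C(F)(F)F)c4)c3)cc2-c2ccncc2)ccc1Cl` gives > 32500 nM

In a functional assay on 786-0 cells (Homo sapiens) for inhibition, read by sulforhodamine B assay, with a stated time of 48 h (on this read-out higher numbers stand for lower toxicity in this test and lower numbers for higher toxicity in this test), compound 1 gives > 32500 nM, which is a limit of the test and not a number. In this assay compound 2 likewise gives > 32500 nM, again a limit and not a number. Compound 2 thus stands at the ceiling of the read-out alongside compound 1, as shown by the limit of > 32500 nM in this assay, at which 2 of the 2 values shown sit. Within the data shown here, no step between measured compounds is available, since neither value is a number, so nothing sets a size for any structural change.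

Compound 3 `COc1cc(-c2nn(-c3cccc(NC(=O)c4cccc(C(F)(F)F)c4)c3)cc2-c2ccncc2)ccc1Cl` is not yet measured. It differs from compound 2 by hydrogen in place of chloro on an aromatic carbon. Both measured values sit at the limit, and no evidence points to this change moving the read-out either way, so the step from compound 2 to compound 3 is expected to be a step that the limit leaves unreadable from compound 2 to compound 3, none beyond the scatter. Compound 3 is therefore estimated at 40000 nM, with a range from 15000 nM to 100000 nM, and the test is expected most likely to report only a limit again.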

Compound 3, concentration lethal to 50% of the cells: > 50000 nM
Compound 3 gave a limit, no number; the forecaster's own chance of this, stated with the estimate: 75%; middle value at least 1.2-fold (0.09 log units) from the limit.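

In this assay compound 3 gives > 50000 nM, a limit of the test and not a number. Compound 2 also sits at a limit, and no size can be read for the step between compound 2 and compound 3. The compounds shown leave open whether any change in this series would bring the read-out to a measurable value.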